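Imidazole series: a methyl on the imidazolyl ring

The compounds below may be only part of what the source reports. "The series", "measured", "known", "first", "only" and "open" are said of these compounds alone.

Compound 2 `Cc1cc(-n2ccnc2)c(S(C)(=O)=O)cc1C(=O)N=C(N)N` gives 23 nM in a functional assay for inhibition of sodium/hydrogen exchanger (Oryctolagus cuniculus) (on this read-out higher numbers stand for weaker inhibition and lower numbers for stronger inhibition), and stands lowest of the two numbers in hand; its nearest neighbour is compound 1 `Cc1cc(-c2cc(Cl)cc(Cl)c2)c(S(C)(=O)=O)cc1C(=O)N=C(N)N`, which in this assay gives 130 nM. Among the compounds with values here, the single measured step, a 5.7-fold lower number from compound 1 to compound 2 (0.75 log units; beyond the scatter), concerns the exchange of the aryl group on the shared core and leaves the imidazole ring itself untouched. Compound 3 `Cc1cc(-n2ccnc2C)c(S(C)(=O)=O)cc1C(=O)N=C(N)N` differs from compound 2 by methyl in place of hydrogen on an aromatic carbon. Within the data shown here, no measured pair alters this ring, so no step bears directly on the change; the step from compound 1 to compound 2 shows only that the 1H-imidazol-1-yl group carries the lower number, not how a methyl placed on it would read. Among the measured compounds shown here, with no relevant precedent, the expectation for compound 3 in this assay is a step of a 1.1-fold higher number from compound 2 to compound 3 (0.04 log units; within the scatter), that is, none beyond the scatter. Compound 3 is therefore estimated at 25 nM in this assay, with a range from 8 nM to 80 nM reflecting the open question.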

Compound 3, half-maximal inhibitory concentration: 29 nM
Estimate against measurement, compound 3: 1.2-fold (0.06 log units) below; low and high end bracket the measured number.
By their numbers in this assay, from the lowest: compounds 2 and 3 (each within the scatter of the next); then compound 1.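

In this assay, methyl in place of hydrogen on the aromatic carbon between two ring nitrogen atoms, next to the ring atom that bears a large group, gives no difference beyond the scatter (a 1.3-fold higher number from compound 2 to compound 3 (0.10 log units; within the scatter)), so this carbon of the 1H-imidazol-1-yl group can carry a methyl without a measurable shift in the number. The 2-methyl-1H-imidazol-1-yl group also keeps the series apart from the 3,5-dichlorophenyl group (a 4.5-fold lower number from compound 1 to compound 3 (0.65 log units; beyond the scatter)), so the lower number seen with the imidazole ring is not confined to the form without the methyl. Nothing at hand gives a measured property or other explanation for this reading.

With a single small group on a single ring carbon, the compounds shown do not tell how far this position accepts larger or different groups, such as an ethyl, a longer chain, an amine or a carboxylic acid. Going by these compounds, a methyl on either of the other two carbons of the imidazole ring also remains open, as does whether the same reading would hold with a different aryl or heteroaryl group on the shared core.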